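A few compounds are considered here, and "the series" means these few. Any claim that something is new, unique, unknown or untested is made for them only; others in the source may bear on it.

In a functional assay on LNCaP cells (Homo sapiens) for antiproliferative activity, read by MTT assay, with a stated time of 96 h (a higher number here means a weaker inhibitor, a lower number a stronger inhibitor), compound 1 `FC(F)(F)Oc1cccc(Nc2nnnc3ccc(N4CCCC4)nc23)c1` gives > 100000 nM, which is a limit of the assay and not a number. Going by the values given here, compound 2 `CC(C)N1CCN(c2ccc3nnnc(Nc4cccc(OC(F)(F)F)c4)c3n2)CC1` gives 10700 nM, the only true number available so far. Compound 3 `FC(F)(F)Oc1cccc(Nc2nnnc3ccc(NCC4CCNCC4)nc23)c1` keeps the shared core and the rest of compound 2, but has ((piperidin-4-yl)methyl)amino in place of 4-isopropylpiperazin-1-yl on an aromatic carbon. Among the compounds with values here, only one measured step bears on this change. Swapping pyrrolidin-1-yl for 4-isopropylpiperazin-1-yl at the same place gave an at least 9.3-fold lower number from compound 1 to compound 2 (0.97 log units; beyond the scatter), and its true size stays open, as the limit of > 100000 nM in this assay, at which 1 of the 2 values shown sits, shows. That step suggests the group at this place can matter in this assay, but it involves neither the entering group nor any move away from compound 2. It therefore gives no firm direction, and the expectation is a change that stays within the scatter, with wide uncertainty on either side. The expected change is a 1.5-fold lower number from compound 2 to compound 3 (0.18 log units; within the scatter). For compound 3 the estimated value is 7000 nM, within an expected range from 1500 nM to 35000 nM.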

Compound 3, half-maximal inhibitory concentration: 11500 nM
Compound 3: middle estimate off by 1.6-fold (0.22 log units), on the low side; measured number inside the range.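

In this assay, putting ((piperidin-4-yl)methyl)amino in place of 4-isopropylpiperazin-1-yl gives a 1.1-fold higher number from compound 2 to compound 3 (0.03 log units; within the scatter), so the two groups cannot be told apart here, even though the entering group carries hydrogen-bond donors and the leaving group has none. Set against pyrrolidin-1-yl, the same entering group gives an at least 8.6-fold lower number from compound 1 to compound 3 (0.93 log units; beyond the scatter), which shows that the earlier gain at this place is not tied to 4-isopropylpiperazin-1-yl alone: two differently built groups now stand apart from the pyrrolidin-1-yl of compound 1. The true size of both steps away from compound 1 stays open because its value is a limit of the assay and not a number: the limit of > 100000 nM in this assay, at which 1 of the 3 values shown sits.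

Compound 2 and compound 3 each bring two nitrogens in the group at this place, so the compounds shown cannot say whether the nitrogen further from the shared core matters. A morpholin-4-yl group, with a ring oxygen instead of that nitrogen, or a simple open-chain amine such as 2-(dimethylamino)ethylamino, would help separate the role of that nitrogen from the role of the ring.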